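Swapping ethylamino for isopropoxy on a weak kinase inhibitor

A few compounds are considered here, and "the series" means these few. Any claim that something is new, unique, unknown or untested is made for them only; others in the source may bear on it.

Measured compounds:
- compound 1 `CCNc1cc(-c2cccnc2)ccc1C(N)=O`: 58000 nM
- compound 2 `NC(=O)c1ccc(-c2cncc(Cl)c2)cc1`: 14200 nM

In an assay on cells for inhibition of MAP kinase-interacting serine/threonine-protein kinase 1 (Homo sapiens), read by mobility shift assay, with stated times of 10 min and 60 min, in the presence of a further agent that is not named here (on this read-out higher numbers stand for weaker inhibition and lower numbers for stronger inhibition), compound 1 gives 58000 nM, the highest of the two numbers measured. Going by the values given here, its nearest neighbour is compound 2, whose value of 14200 nM lies beyond the scatter from it; no single-point step connects the two, so only the two values themselves can be read.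

Compound 3 `CC(C)Oc1cc(-c2cccnc2)ccc1C(N)=O` is not yet measured. It differs from compound 1 in one place: isopropoxy in place of ethylamino on an aromatic carbon. Among the compounds with values here, no measured pair shows what this kind of swap does, so the direction of the step is open. The step of a 1.2-fold higher number from compound 1 to compound 3 (0.08 log units; within the scatter) is expected to stay close to the scatter, as a small drift rather than a clear shift. Compound 3 is therefore estimated at 70000 nM, within a range from 20000 nM to 250000 nM.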

Compound 3, half-maximal inhibitory concentration: 880 nM
The estimate for compound 3 lay 80-fold (1.90 log units) above the measured number; the whole stated range lies above it.
By their numbers in this assay, from the lowest: compound 3; then compound 2; then compound 1.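

In this assay, placing isopropoxy instead of ethylamino on the aromatic carbon ortho to the carbamoyl group gives a 66-fold lower number from compound 1 to compound 3 (1.82 log units; beyond the scatter), so the group at this position can change the number by a large step. The swap changes several things at once: ethylamino has 1 hydrogen-bond donor and isopropoxy has 0, the atom attached to the ring changes from nitrogen to oxygen, and the chain changes from ethyl to isopropyl. Nothing shown here explains why the step is so large.

These compounds leave open whether the oxygen or the isopropyl chain accounts for the step, a question that an ethoxy or an isopropylamino group at the same position could help to separate. They also leave open whether a longer chain, such as a butoxy group, would lower the number further.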